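This account rests on a few compounds, and the source may have more. Where it says the series, first, only, none or still open, it means among the compounds named here.

Compound 3 `CCOC(=O)C1=Cc2ccccc2OC1(OCc1cn(CC(=O)Nc2ccccc2Br)nn1)C(F)(F)F` stands at the weak end of the three measured compounds: in a functional assay on A549 cells (Homo sapiens) for inhibition, read by MTT assay, with a stated time of 24 h (a lower number here means a stronger inhibitor, a higher number a weaker inhibitor), compound 3 gives > 150000 nM, which is a limit of the assay and not a number. Compound 1 `CCOC(=O)C1=Cc2ccccc2OC1(OCc1cn(CC(=O)Nc2ccc(OC)cc2)nn1)C(F)(F)F` gives 29400 nM. Compound 2 `CCOC(=O)C1=Cc2ccccc2OC1(OCc1cn(-c2ccccc2)nn1)C(F)(F)F` gives > 150000 nM, again a limit. Two of the three values therefore sit at the limit of > 150000 nM in this assay, at which 2 of the 3 values shown sit. The steps of an at least 5.1-fold higher number from compound 1 to compound 2 (0.70 log units; beyond the scatter) and an at least 5.1-fold higher number from compound 1 to compound 3 (0.70 log units; beyond the scatter) both run toward that limit, while a step that the two limits leave unreadable from compound 2 to compound 3. Compound 4 `CCOC(=O)C1=Cc2ccccc2OC1(OCc1cn(CC(=O)Nc2ccccc2F)nn1)C(F)(F)F` differs from compound 3 by fluoro in place of bromo on an aromatic carbon. For the measured compounds named here, no measured step exchanges one halogen for another on that ring; the nearest comparison is an at least 5.1-fold higher number from compound 1 to compound 3 (0.70 log units; beyond the scatter), where the 2-bromophenyl amide already reached the limit. Compound 4 is therefore expected to remain near the limit, with an at least 1.2-fold lower number from compound 3 to compound 4 (0.09 log units; that floor lies within the scatter) expected to be small. Compound 4 is estimated at 120000 nM, between 30000 nM and 300000 nM.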

Compound 4, half-maximal inhibitory concentration: 50100 nM
For compound 4 the middle estimate is 2.4-fold (0.38 log units) above the measured one; measured number inside the range.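

In this assay, the halogen on this ring matters: with fluoro in place of bromo, ortho to a large group, the series shows an at least 2.9-fold lower number from compound 3 to compound 4 (0.47 log units; beyond the scatter). The (2-fluorophenyl)carbamoyl group on the aromatic nitrogen also separates from phenyl, with an at least 2.9-fold lower number from compound 2 to compound 4 (0.47 log units; beyond the scatter). With a 1.7-fold higher number from compound 1 to compound 4 (0.23 log units; within the scatter), 2-fluorophenyl and 4-methoxyphenyl on the amide-type nitrogen cannot be told apart, so a group at this place need not push the value to the limit.

The full size of the steps from compound 2 and compound 3 stays unread, as both values are limits of the assay: the limit of > 150000 nM in this assay, at which 2 of the 4 values shown sit. On these data alone, whether chloro or an amine at this place falls with fluoro or with bromo remains open.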